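The source may report more compounds than this note shows. Statements on the series, on what has been measured and on what is new or still open speak of the compounds shown alone.

Compound 1 `C=C(C)C(CC[C@@]1(C)C(CC[C@H]2[C@]3(C)CC[C@H](O)C(C)(C)O[C@H]3CC[C@@]2(C)O)=C(C)CC[C@H]1O)OO`: 31200 nM
Compound 2 `CC1=CC[C@H]2[C@H](CC[C@]2(C)O)C(C)(C)[C@@H]1CC[C@H]1[C@]2(C)CC[C@@H](O)O[C@H]2CC[C@@]1(C)O`: > 50000 nM, a limit of the assay and not a number

Within the data shown here, in a functional assay on MCF7 cells (Homo sapiens) for antiproliferative activity, read by MTT assay, with a stated time of 72 h (on this read-out higher numbers stand for weaker inhibition and lower numbers for stronger inhibition), compound 1 holds the only true number so far, 31200 nM. Compound 3 `CC1=C(CC[C@H]2[C@]3(C)CC[C@H](O)C(C)(C)O[C@H]3CC[C@@]2(C)O)[C@](C)(C/C=C/C(C)(C)OO)[C@H](O)CC1` keeps the core of compound 1 and exchanges one side group: a group of 7 heavy atoms (5 carbon, 2 oxygen; no ring) in place of a group of 7 heavy atoms (5 carbon, 2 oxygen; no ring), on a saturated chain carbon bound to a saturated ring carbon. The two compounds have the same atoms, joined differently. Among the measured compounds shown here, no measured pair shows what such a change does, so the expectation rests on compound 1 at 31200 nM, with no shift beyond the usual scatter. The expected 1.0-fold lower number from compound 1 to compound 3 (0.02 log units; within the scatter) is therefore small. For compound 3 the estimate is 30000 nM, with an expected range of 12000 nM to 50000 nM.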

Compound 3, half-maximal inhibitory concentration: 27400 nM
The estimate for compound 3 lay 1.1-fold (0.04 log units) above the measured number, within the range that was stated.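

In this assay, among these compounds, this is the first measured pair, and it gives a first reading of this place, on a saturated chain carbon bound to a saturated ring carbon: a 1.1-fold lower number from compound 1 to compound 3 (0.06 log units; within the scatter). The two side groups hold the same atoms, joined differently, and this rearrangement leaves compound 1 and compound 3 indistinguishable on this read-out.

On these data alone, whether a different group at this place, such as an amine or a carboxylic acid, would shift the number stays open. A weaker compound might also give no true number: the limit of > 50000 nM in this assay, at which 1 of the 3 values shown sits.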